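A Second Chloro on the Benzyl Group of Compound 1

The source may hold more compounds than are shown below. What is called first, only, known or untested is meant among the compounds shown, and "the series" means these compounds.

compound 1, `N[C@H]1CC[C@H](Nc2c(C(=O)NCc3ccc(Cl)cc3)nc(Br)c3cccnc23)CC1`: 2000 nM
compound 2, `NCCCNc1c(C(=O)NCc2ccc(F)cc2)ncc2cccnc12`: > 10000 nM

Within the data shown here, in a functional assay on SK-BR-3 cells (Homo sapiens) for cytotoxicity, read by MTT assay, with a stated time of 72 h (a lower number here means a stronger inhibitor, a higher number a weaker inhibitor), compound 1 gives 2000 nM, the only number among the values shown. Compound 2 reaches (the limit of > 10000 nM in this assay, at which 1 of the 2 values shown sits), which is a limit of the assay and not a number. Compound 3 `N[C@H]1CC[C@H](Nc2c(C(=O)NCc3ccc(Cl)cc3Cl)nc(Br)c3cccnc23)CC1` differs from compound 1 by chloro in place of hydrogen on an aromatic carbon. Among the measured compounds shown here, no step between measured compounds is available for this change, so it is expected to shift the read-out little, if at all beyond the usual scatter. Compound 3 is therefore estimated at 1500 nM, between 500 nM and 5000 nM, an expected step of a 1.3-fold lower number from compound 1 to compound 3 (0.12 log units; within the scatter) that stays within the scatter.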

Compound 3, half-maximal inhibitory concentration: 6000 nM
Estimate against measurement, compound 3: 4.0-fold (0.60 log units) below; measured number outside the range, above it.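

In this assay, among these compounds, the change from 4-chlorobenzyl to 2,4-dichlorobenzyl gives a 3.0-fold higher number from compound 1 to compound 3 (0.48 log units; beyond the scatter) and so provides the first reading at this position: chloro on this aromatic carbon, ortho to a large group, weakens the compound rather than leaving it unchanged. The position therefore responds to the addition of a single heavy atom. Nothing measured here bears on the cause of this step. The compounds shown leave open whether fluoro, methoxy or an amine on this same carbon would behave like chloro. They also leave open whether chloro elsewhere on this ring would give a similar step.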